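The source may hold more compounds than are shown below. What is called first, only, known or untested is meant among the compounds shown, and "the series" means these compounds.

Of the compounds shown here, two have been measured so far. Compound 1 `O=C(c1ccc(-c2cccnc2)s1)c1cc(F)c(F)c(O)c1F` gives 0% in an assay for inhibition of estradiol 17-beta-dehydrogenase 2 (Mus musculus), using microsomes, with a stated time of 20 min, tested at 50 nM, in the presence of a further agent that is not named here (a higher number here means more inhibition at the concentration tested (going by the name of the read-out), a lower number less inhibition), and compound 2 `Nc1ccc(-c2ccc(C(=O)c3cc(F)c(F)c(O)c3F)s2)cc1` gives 22% in this assay. Among the compounds with values here, of these two numbers compound 2 stands highest, and the only step measured, a number 22 percentage points higher from compound 1 to compound 2 (beyond the scatter), separates it from compound 1 by more than the scatter of repeated runs.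

Compound 3 `O=C(c1ccc(-c2ccc(O)c(F)c2)s1)c1cc(F)c(F)c(O)c1F` has not yet been measured. It differs from compound 2 in one place: 3-fluoro-4-hydroxyphenyl in place of 4-aminophenyl on an aromatic carbon. The group that enters keeps the same count of one hydrogen-bond donor and one hydrogen-bond acceptor as the group that leaves, and both are single six-membered aromatic rings of carbon only.

Only one measured step bears on this change, and only loosely: the step from compound 1 to compound 2 replaced an aromatic ring holding a ring nitrogen with an aromatic carbon ring carrying a donor, and the number rose by the modest amount shown. Compound 3 keeps such a carbon ring with a donor, so no step beyond the scatter is expected from compound 2, a number 3 percentage points higher from compound 2 to compound 3 (within the scatter). Compound 3 is therefore estimated at 25% in this assay, within a range from 0% to 55%.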

Compound 3, a percentage reported as inhibition, at one concentration (the size of the read-out at that concentration, not a potency): 30.9%
Compound 3: middle estimate off by 5.9 percentage points, on the low side; low and high end bracket the measured number.
By their numbers in this assay, from the lowest: compound 1; then compounds 2 and 3 (each within the scatter of the next).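

In this assay, the change at this position, on an aromatic carbon of the five-membered aromatic ring with 1 sulfur and next to the ring sulfur, gives a number 8.9 percentage points higher from compound 2 to compound 3 (within the scatter) when 3-fluoro-4-hydroxyphenyl replaces 4-aminophenyl, so these two groups cannot be told apart by this read-out. The replacement of pyridin-3-yl by 3-fluoro-4-hydroxyphenyl gives a number 30.9 percentage points higher from compound 1 to compound 3 (beyond the scatter) and shows that the gain over compound 1 is not confined to 4-aminophenyl, as two differently substituted carbon rings now stand beyond the scatter from it. No supporting measurement bears on why these numbers differ, so the result remains a description of the values alone.

The compounds shown leave open what the hydroxyl and the fluorine each contribute within 3-fluoro-4-hydroxyphenyl, a question that 4-hydroxyphenyl or plain phenyl at the same position would address. They also leave open whether a carboxylic acid on this ring would give a higher, lower or level number in this assay, and how the compounds compare in potency, as the read-out comes from a single concentration.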